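The compounds below may be only part of what the source reports. "The series", "measured", "known", "first", "only" and "open" are said of these compounds alone.

Compound 2 `COc1ccc(-c2cc3ccccc3nc2/C=C/C(=O)c2ccc(OC)cc2OC)cc1` is the higher of the two numbers measured here. In a functional assay on SK-BR-3 cells (Homo sapiens) for antiproliferative activity, read by XTT assay, with a stated time of 72 h (a higher number here means a weaker inhibitor, a lower number a stronger inhibitor), compound 2 gives 2260 nM, whereas compound 1 `COc1ccc(-c2cc3ccccc3nc2/C=C/C(=O)c2ccc(F)cc2)cc1` gives 810 nM. Among the compounds with values here, the only step between measured compounds is a 2.8-fold higher number from compound 1 to compound 2 (0.45 log units; beyond the scatter), so compound 2 stands at the top, with compound 1 as its nearest neighbour and nothing else to compare against.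

Compound 3 `COc1ccc(-c2cc3ccccc3nc2/C=C/C(=O)c2ccc(N)cc2)cc1` differs from compound 2 by 4-aminophenyl in place of 2,4-dimethoxyphenyl on a carbonyl carbon. Within the data shown here, the one measured step bears directly on this change, since it also swapped the aryl group on the carbonyl carbon: there, replacing 4-fluorophenyl with 2,4-dimethoxyphenyl raised the number by a modest amount. Returning from 2,4-dimethoxyphenyl to a ring carrying a single substituent, here 4-aminophenyl, is therefore expected to move the number back down in this assay, by a modest step of roughly the size seen before, though the amino group has no precedent among the measured compounds and the range must stay wide. For compound 3 the estimated step is a 2.3-fold lower number from compound 2 to compound 3 (0.35 log units; beyond the scatter). Compound 3 is expected to give about 1000 nM, between 400 nM and 3000 nM.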

Compound 3, half-maximal inhibitory concentration: 8560 nM
Compound 3: middle estimate off by 8.6-fold (0.93 log units), on the low side, and the stated range ends below it.
By their numbers in this assay, from the lowest: compound 1; then compound 2; then compound 3.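

In this assay the new result shows that the aryl group on the carbonyl carbon is not ordered simply by how many substituents it carries: the step gives a 3.8-fold higher number from compound 2 to compound 3 (0.58 log units; beyond the scatter) on going to 4-aminophenyl, so a ring with one substituent can stand above 2,4-dimethoxyphenyl, while compound 1, also with one substituent, stands below it. Within the data shown here, the identity of the single group therefore matters more than the first step could show, and amino in place of fluoro on an aromatic carbon gives an 11-fold higher number from compound 1 to compound 3 (1.02 log units; beyond the scatter) in the largest step seen so far. With both its steps printed as beyond the scatter, compound 3 is the weakest of the three in this assay, and nothing on hand explains this order.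

The compounds shown leave open whether a hydroxyl, a chlorine or a dimethylamino group in place of the amino would fall nearer compound 1 or nearer compound 3. They also leave open how each of the two methoxy groups of compound 2 contributes on its own.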